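The compounds below may be only part of what the source reports. "The series", "measured", "known", "first", "only" and "open" are said of these compounds alone.

Measured so far:
compound 1 `CCCCCCNNC(=O)c1cccc(NCc2ccccc2)c1` — 46 nM
compound 2 `CCCCNNC(=O)c1ccc(-c2ccc(CNC(C)=O)cc2)cc1` — 360 nM

In an assay on isolated protein for inhibition of histone deacetylase 8 (Homo sapiens), read by fluorescence, with a stated time of 5 min (a higher number here means a weaker inhibitor, a lower number a stronger inhibitor), compound 2 gives 360 nM, the higher of the two numbers; compound 1 gives 46 nM. Compound 3 `CCCNNC(=O)c1ccc(-c2ccc(CNC(C)=O)cc2)cc1` differs from compound 2 in one place: hydrogen in place of methyl on a saturated chain carbon, three bonds along the chain from an amine nitrogen. Going by the values given here, no step between two measured compounds shows what this change does, so the direction is open. In this assay the step is expected to be small, with the estimated step of a 1.2-fold higher number from compound 2 to compound 3 (0.07 log units; within the scatter) not clearly beyond the scatter. Compound 3 is expected to give 420 nM, within a range from 150 nM to 1200 nM.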

Compound 3, half-maximal inhibitory concentration: 700 nM
The estimate for compound 3 lay 1.7-fold (0.22 log units) below the measured number, and the stated range covers the measured number.
By their numbers in this assay, from the lowest: compound 1; then compounds 2 and 3 (each within the scatter of the next).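

In this assay, going by these compounds alone, this gives the first reading at this position: butyl to propyl, hydrogen in place of methyl on a saturated chain carbon, three bonds along the chain from an amine nitrogen, is a 1.9-fold higher number from compound 2 to compound 3 (0.29 log units; within the scatter). Shortening the chain by this one carbon therefore does not separate compound 2 and compound 3 beyond the scatter. Nothing measured here accounts for the step.

On these data alone, what a longer chain on the core of compound 2 would do in this assay remains open. So does the effect of an amine or a carboxylic acid on this chain.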